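The source may report more compounds than this note shows. Statements on the series, on what has been measured and on what is new or still open speak of the compounds shown alone.

Compound 1 `COc1ccc(-c2csc(NC(=O)COc3ccc(C(=O)c4ccccc4)cc3C)n2)cc1` is the parent of this small set. In a functional assay on DLA cells (Mus musculus) for cytotoxicity, read by MTT assay, with a stated time of 48 h (a higher number here means a weaker inhibitor, a lower number a stronger inhibitor), compound 1 gives 25700 nM. Compound 2 `COc1ccc(-c2csc(NC(=O)COc3ccc(C(=O)c4ccc(F)cc4)cc3C)n2)cc1` gives 5400 nM, and compound 3 `COc1ccc(-c2csc(NC(=O)COc3ccc(C(=O)c4cccc(Br)c4)cc3C)n2)cc1` gives 36600 nM. Of the three numbers, compound 3 has the highest, meaning the weakest inhibition; its nearest neighbour is compound 1, and that gap lies within the scatter, while the gap to compound 2 lies beyond it, as seen in a 6.8-fold higher number from compound 2 to compound 3 (0.83 log units; beyond the scatter).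

Compound 4 `COc1ccc(-c2csc(NC(=O)COc3ccc(C(=O)c4cccc(F)c4)cc3C)n2)cc1` is not yet measured. The change from compound 3 is fluoro in place of bromo on an aromatic carbon. For the measured compounds named here, no measured step exchanges these two groups directly. Going by the values given here, two steps bear on it. A bromo entering in place of hydrogen gave a 1.4-fold higher number from compound 1 to compound 3 (0.15 log units; within the scatter), a change within the scatter, so removing it should change little. A fluoro entering in place of hydrogen gave a 4.8-fold lower number from compound 1 to compound 2 (0.68 log units; beyond the scatter), a modest gain, though that fluoro sat elsewhere on the ring. Weighing both, the expected outcome for compound 4 is a 2.4-fold lower number from compound 3 to compound 4 (0.39 log units; beyond the scatter), a step near the edge of the scatter and pointing toward stronger inhibition. Compound 4 is therefore estimated at 15000 nM, with a range from 5000 nM to 45000 nM.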

Compound 4, half-maximal inhibitory concentration: 28400 nM
The estimate for compound 4 lay 1.9-fold (0.28 log units) below the measured number; the measured number falls inside the stated range.
By their numbers in this assay, from the lowest: compound 2; then compounds 1, 4 and 3 (each within the scatter of the next).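

Exchanging the bromo for fluoro gives a 1.3-fold lower number from compound 3 to compound 4 (0.11 log units; within the scatter) in this assay, and fluoro in place of hydrogen on the same carbon, the one meta to a large group, gives a 1.1-fold higher number from compound 1 to compound 4 (0.04 log units; within the scatter). Hydrogen, bromo and fluoro on this carbon therefore cannot be told apart in these compounds, so this position has so far shown no response to the change of group. Fluoro alone is also not enough to account for the stronger inhibition of compound 2, the strongest of the four, since 3-fluorophenyl in place of 4-fluorophenyl gives a 5.3-fold higher number from compound 2 to compound 4 (0.72 log units; beyond the scatter), and in this set the gain goes with the 4-fluorophenyl group and not with fluoro wherever it sits.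

Nothing measured here gives a reason for this difference between the two fluoro placements. Still open, going by these compounds, is whether a chloro, an amine or a carboxylic acid in the place of the fluoro of compound 2 would keep its gain, and whether any of these groups on the carbon that carries the bromo of compound 3 would move the number beyond the scatter.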